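The source may report more compounds than this note shows. Statements on the series, on what has been measured and on what is new or still open speak of the compounds shown alone.

All four compounds share one core and differ only in the group on a saturated chain carbon bound to an amine nitrogen in a ring. Compound 1 `CCCCCCCN1CCC(C(=O)Nc2cc(Cl)c(N)cc2OC)CC1` carries a hexyl there. In a functional assay on the whole organism for antagonist activity, with Mus musculus as the target (on this read-out higher numbers stand for an effect only at larger amounts of compound and lower numbers for an effect already at smaller amounts), compound 1 reaches only a limit, > 10 mg/kg, so no number is known for it. Compound 2 `COc1cc(N)c(Cl)cc1NC(=O)C1CCN(Cc2ccc(F)cc2)CC1` carries a 4-fluorophenyl, and in this assay compound 2 gives 0.6 mg/kg. Compound 3 `COc1cc(N)c(Cl)cc1NC(=O)C1CCN(Cc2ccccc2F)CC1` carries a 2-fluorophenyl. In this assay compound 3 likewise stands at a limit, > 4 mg/kg, so compound 3 is known only as a bound and not as a number. The measured steps run an at least 16-fold lower number from compound 1 to compound 2 (1.22 log units; beyond the scatter), an at least 6.6-fold higher number from compound 2 to compound 3 (0.82 log units; beyond the scatter) and a step that the two limits leave unreadable from compound 1 to compound 3.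

Compound 4 `COc1ccc(CN2CCC(C(=O)Nc3cc(Cl)c(N)cc3OC)CC2)cc1` differs from compound 3 by 4-methoxyphenyl in place of 2-fluorophenyl on a saturated chain carbon bound to an amine nitrogen in a ring. Among the measured compounds shown here, the one compound with a number, compound 2, carries a 4-fluorophenyl, and the 4-methoxyphenyl of compound 4 swaps only its fluorine for a methoxy, whereas the 2-fluorophenyl of compound 3 gave an at least 6.6-fold higher number from compound 2 to compound 3 (0.82 log units; beyond the scatter). The change is therefore expected to bring the number back down, as an at least 3.3-fold lower number from compound 3 to compound 4 (0.52 log units; beyond the scatter). Compound 4 is expected near 1.2 mg/kg, within 0.3 mg/kg to 5 mg/kg.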

Compound 4, dose for half-maximal effect: 0.9 mg/kg
Estimate against measurement, compound 4: 1.3-fold (0.12 log units) above; low and high end bracket the measured number.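

Methoxy in place of fluoro on an aromatic carbon gives a 1.5-fold higher number from compound 2 to compound 4 (0.18 log units; within the scatter), so among the compounds shown, a low number in this assay at this place does not depend on the fluoro. The 4-methoxyphenyl also sets itself apart from the other two groups, with an at least 11-fold lower number from compound 1 to compound 4 (1.04 log units; beyond the scatter) and an at least 4.4-fold lower number from compound 3 to compound 4 (0.64 log units; beyond the scatter), so compound 2 no longer stands alone against the hexyl and the 2-fluorophenyl. Each of these two steps starts from a limit and not a number, that of compound 3 being this: the limit of > 4 mg/kg in this assay, at which 1 of the 4 values shown sits.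

Going by these compounds, how high the number of compound 3 really lies remains unknown. On these data alone, it also remains open whether a 2-methoxyphenyl would read like the 2-fluorophenyl or like the 4-methoxyphenyl, and how an unsubstituted phenyl or a 4-chlorophenyl would read at this place.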